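The compounds below may be only part of what the source reports. "The series", "measured", "known", "first", "only" and "open" are said of these compounds alone.

Compound 1 `CCOCCCCc1[nH]c2ccc([N+](=O)[O-])cc2c(=O)c1C(=O)OCC`: 5000 nM
Compound 2 `CCCCCCCc1[nH]c2ccc([N+](=O)[O-])cc2c(=O)c1C(=O)O`: 15000 nM

In a physicochemical assay for solubility, read by HPLC, at pH 7.4 (a lower number here means a less soluble compound, a higher number a more soluble compound), compound 2 gives the higher of the two numbers, and its gap to compound 1 lies beyond the scatter. Compound 3 `CCOCCCCc1[nH]c2ccc([N+](=O)[O-])cc2c(=O)c1C(=O)O` alters the chain of compound 2: ethoxy in place of propyl on a saturated chain carbon, four bonds along the chain from an aromatic carbon. For the measured compounds named here, no measured pair shows a single change, so the expectation here is a judgement from the structures alone. The expected result is a modest rise, close to the scatter, a 2.0-fold higher number from compound 2 to compound 3 (0.30 log units; within the scatter). Compound 3 is estimated at 30000 nM, with an expected range of 12000 nM to 80000 nM.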

Compound 3, solubility: 50000 nM
The estimate for compound 3 lay 1.7-fold (0.22 log units) below the measured number, within the range that was stated.
By their numbers in this assay, from the lowest: compound 1; then compound 2; then compound 3.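

In this assay ethoxy in place of propyl on a saturated chain carbon, four bonds along the chain from an aromatic carbon, gives a 3.3-fold higher number from compound 2 to compound 3 (0.52 log units; beyond the scatter) as a single change, so this chain position alone can move the number. Hydrogen in place of ethyl on an oxygen gives a 10-fold higher number from compound 1 to compound 3 (1.00 log units; beyond the scatter) with the chain held the same, so a second place in the molecule moves it too. Nothing measured here gives a cause for either step. Still open, on these data alone, is whether an amine at the same chain carbon would shift the number as ethoxy does. A longer chain carrying ethoxy would show whether the effect holds further out.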